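From a five-membered ring group to a four-membered one

This account rests on a few compounds, and the source may have more. Where it says the series, first, only, none or still open, it means among the compounds named here.

Compound 1 `COc1cc(NC(C)CCCN/C(C)=C2/CCOC2=O)c2ncccc2c1` – "not determined" (no result reported)
Compound 2 `CCCCOc1c(NCCC(C)Nc2cc(OC)cc3cccnc23)c(=O)c1=O` – > 100000 nM
Compound 3 `CCOc1c(NCCCC(C)Nc2cc(OC)cc3cccnc23)c(=O)c1=O` – not yet measured

Compound 1 offers no number to start from: in an ADME assay on HEK-293T cells (Homo sapiens) for cytotoxicity, read by MTT assay, with a stated time of 48 h (a lower number here means a stronger inhibitor, a higher number a weaker inhibitor), compound 1 stands as "not determined" (no result reported) and so has no place on the scale. Compound 2 reads > 100000 nM here, and this is a limit, not a number.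

Compound 3 differs from compound 1 in one place. The change is a group of 9 heavy atoms (6 carbon, 3 oxygen; one four-membered aromatic ring of carbon only) in place of a group of 8 heavy atoms (6 carbon, 2 oxygen; one five-membered non-aromatic ring with 1 hetero atom), on an amine nitrogen. The entering group brings one four-membered aromatic ring of carbon only, where one five-membered non-aromatic ring with 1 hetero atom stood.

Without a number for compound 1, a step in this assay has no measured start, so the working expectation is a step of no size beyond the scatter and no set direction. For the measured compounds named here, the only other guide is compound 2, whose reading of > 100000 nM is a limit. A weak effect on these cells is therefore expected for compound 3 too, and its reading may also end as a limit. For compound 3 the estimated value is 90000 nM, with an expected range from 30000 nM to 200000 nM.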

Compound 3, half-maximal inhibitory concentration: > 100000 nM
Compound 3 gave a limit, no number (the forecaster's own chance of this, stated with the estimate: 65%); middle value at least 1.1-fold (0.04 log units) from the limit.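

No step can be read from compound 1 to compound 3 in this assay, and compound 1 has no result there. Compound 3 reads > 100000 nM, which is a limit and not a number. The compounds shown leave open how strongly, if at all, either ring group acts on these cells, as the readings stop at one mark: the limit of > 100000 nM in this assay, at which 2 of the 3 values shown sit.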